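A Smaller Group on the Sulfonyl Sulfur of Compound 1

The compounds below may be only part of what the source reports. "The series", "measured", "known", "first", "only" and "open" are said of these compounds alone.

Compound 1 `O=S(=O)(Nc1ccc2oc(-c3ccccc3)nc2c1)c1ccccc1O` was tested in an assay on isolated protein for inhibition of malate dehydrogenase, mitochondrial (Sus scrofa), with stated times of 45 min and 30 min; on this read-out higher numbers stand for weaker inhibition and lower numbers for stronger inhibition. In this assay compound 1 gives > 63000 nM, which is a limit of the assay rather than a measured number. Two related compounds share this outcome. Compound 2 `O=S(=O)(Nc1ccc(-c2nc3ccccc3o2)cc1)c1ccccc1O` carries the same groups arranged differently on the shared core. In this assay compound 2 gives > 63000 nM, again a limit. Compound 3 `O=S(=O)(Nc1ccc(-c2nc3ccccc3o2)cc1)c1ccc(Cl)s1` has 5-chlorothiophen-2-yl in place of 2-hydroxyphenyl on a sulfonyl sulfur. In this assay compound 3 gives > 63000 nM, also a limit. The step that the two limits leave unreadable from compound 2 to compound 3 cannot be read: both of its ends are limits. All values seen so far sit at the limit of > 63000 nM in this assay, at which 3 of the 3 values shown sit.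

Compound 4 `CS(=O)(=O)Nc1ccc2oc(-c3ccccc3)nc2c1` differs from compound 1 in one place: methyl in place of 2-hydroxyphenyl on a sulfonyl sulfur. Within the data shown here, no measured step follows this particular change, and the single step recorded, a step that the two limits leave unreadable from compound 2 to compound 3, offers no size for comparison. With compound 1 already at a limit, the step that the limit leaves unreadable from compound 1 to compound 4 is expected to leave compound 4 without readable inhibition as well. Compound 4 is therefore estimated at 100000 nM, between 30000 nM and 500000 nM, with the assay most likely reporting only a limit once more.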

Compound 4, half-maximal inhibitory concentration: > 63000 nM
Compound 4: no number, only a limit; the forecaster's own chance of this, stated with the estimate: 85%; the middle value is on the limit's open side.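

In this assay compound 4 gives > 63000 nM as a limit of the assay, not a number. Compound 1 and compound 4 both stand at limits, so no step can be read between them. The compounds shown leave open whether any group on the sulfonyl sulfur gives inhibition that can be read as a number.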